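Working notes: the step from compound 3 to compound 4

The compounds below may be only part of what the source reports. "The series", "measured", "known", "first", "only" and "open" are said of these compounds alone.

Compound 3 `COc1ccc(-c2cc(C(=O)Nc3nc4ccc(Cl)cc4s3)nc3cc(-c4ccccc4)nn23)cc1OC` gives 6910 nM in a functional assay on MCF7 cells (Homo sapiens) for cytotoxicity, read by MTT assay, with a stated time of 48 h (on this read-out lower numbers stand for stronger inhibition and higher numbers for weaker inhibition), the second highest of the three numbers; compound 2 `COc1ccc(-c2cc(C(=O)Nc3nc4ccc(Cl)cc4s3)nc3cc(-c4ccccc4)nn23)cc1` gives 4890 nM and compound 1 `O=C(Nc1nc2ccc(Cl)cc2s1)c1cc(-c2ccc(F)cc2)n2nc(-c3ccccc3)cc2n1` gives 19800 nM. The step of a 1.4-fold higher number from compound 2 to compound 3 (0.15 log units; within the scatter) is within the scatter, while a 2.9-fold lower number from compound 1 to compound 3 (0.46 log units; beyond the scatter) and a 4.0-fold lower number from compound 1 to compound 2 (0.61 log units; beyond the scatter) lie beyond it. Compound 4 `COc1ccc(-c2cc(C(=O)Nc3nc4cc(C)c(C)cc4s3)nc3cc(-c4ccccc4)nn23)cc1OC` differs from compound 3 by 5,6-dimethyl-1,3-benzothiazol-2-yl in place of 6-chloro-1,3-benzothiazol-2-yl on an amide-type nitrogen. Going by the values given here, none of the measured steps touches this part of the molecule; all three concern the fluoro and methoxy changes, so nothing measured bears directly on the new change. The step expected in this assay, a 1.0-fold lower number from compound 3 to compound 4 (0.00 log units; within the scatter), is therefore none beyond the scatter. Compound 4 is estimated at 6900 nM, with a range of 2500 nM to 19000 nM.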

Compound 4, half-maximal inhibitory concentration: 2510 nM
Beside the measured number, compound 4's estimate is 2.7-fold (0.44 log units) above it; low and high end bracket the measured number.
By their numbers in this assay, from the lowest: compounds 4, 2 and 3 (each within the scatter of the next, the first and the last beyond it); then compound 1.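

In this assay, 5,6-dimethyl-1,3-benzothiazol-2-yl in place of 6-chloro-1,3-benzothiazol-2-yl on the amide-type nitrogen gives a 2.8-fold lower number from compound 3 to compound 4 (0.44 log units; beyond the scatter). Going by these compounds alone, the earlier steps concerned only the fluoro and methoxy changes, so this is the first sign that the group on this nitrogen also moves the number. No available evidence accounts for this step.

The step exchanges chloro for the dimethyl pattern in a single change, and the compounds shown do not separate the loss of one from the gain of the other. As far as these compounds go, the effect of a methoxy group or an amine on the 1,3-benzothiazol-2-yl group remains open.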